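Aromatic Substituent Swap in a Maximal Electroshock Series

The source may report more compounds than this note shows. Statements on the series, on what has been measured and on what is new or still open speak of the compounds shown alone.

Measured compounds:
compound 1 `O=C1CCC2(c3ccc(F)cc3)OCCCN12`: 68.7 mg/kg
compound 2 `COc1ccc(C23CCC(=O)N2CCCO3)cc1`: 93.8 mg/kg
compound 3 `O=C1CCC2(c3ccccc3)OCCCN12`: 92 mg/kg

In a functional assay on the whole organism with Mus musculus as the target, in the maximal electroshock model (a higher number here means that more compound is needed for the effect, a lower number that less compound is needed), compound 3 gives 92 mg/kg. Its neighbours differ little: a 1.3-fold higher number from compound 1 to compound 3 (0.13 log units; within the scatter) and a 1.0-fold lower number from compound 2 to compound 3 (0.01 log units; within the scatter), so the three compounds sit within the scatter of one another. Compound 4 `O=C1CCC2(c3ccc(Cl)cc3)OCCCN12` is not yet measured. It differs from compound 3 by chloro in place of hydrogen on an aromatic carbon. Going by the values given here, no measured step introduces chloro, but the two steps that touch the same position, a 1.3-fold higher number from compound 1 to compound 3 (0.13 log units; within the scatter) and a 1.0-fold lower number from compound 2 to compound 3 (0.01 log units; within the scatter), were both within the scatter, so a change within the scatter is expected here too in this assay. The step from compound 3 to compound 4 is estimated as a 1.2-fold lower number from compound 3 to compound 4 (0.09 log units; within the scatter). Compound 4 is therefore expected to give about 75 mg/kg, in a range from 40 mg/kg to 140 mg/kg.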

Compound 4, dose for half-maximal effect: 58 mg/kg
For compound 4 the middle estimate is 1.3-fold (0.11 log units) above the measured one; low and high end bracket the measured number.
By their numbers in this assay, from the lowest: compounds 4, 1, 3 and 2 (each within the scatter of the next).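

In this assay chloro behaves like fluoro and methoxy at this position on the aromatic ring, since a 1.6-fold lower number from compound 3 to compound 4 (0.20 log units; within the scatter) and a 1.6-fold lower number from compound 2 to compound 4 (0.21 log units; within the scatter) and a 1.2-fold lower number from compound 1 to compound 4 (0.07 log units; within the scatter) leave it level with all three earlier compounds. Across hydrogen, fluoro, methoxy and chloro, then, no swap at this position has produced a step beyond the scatter. Still open, on these data alone, is whether an amine, a carboxylic acid or a longer chain in this place would produce such a step. No measurement shown explains why these four groups give such similar numbers.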